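This account rests on a few compounds, and the source may have more. Where it says the series, first, only, none or still open, it means among the compounds named here.

The compounds share the core of compound 1 `Cc1ccc(-n2cc(CNC(=O)c3cccc4c3cnn4C(C)C)nn2)c(C)c1`. In a functional assay on HepG2 cells (Homo sapiens) for inhibition, read by MTT assay, with a stated time of 72 h (a higher number here means a weaker inhibitor, a lower number a stronger inhibitor), compound 1 reaches only the limit of the assay, > 40000 nM, and gives no number. Compound 2 `CC(C)n1ncc2c(C(=O)NCc3cn(Cc4ccc(C(F)(F)F)cc4)nn3)cccc21` likewise stops at the assay limit in this assay, at > 40000 nM. Compound 2 thus stands where every measured value in this set stands: the limit of > 40000 nM in this assay, at which 2 of the 2 values shown sit. No change between two measured compounds is available as a guide. Compound 3 `CC(C)n1ncc2c(C(=O)NCc3cn(Cc4ccc(C(C)(C)C)cc4)nn3)cccc21` differs from compound 2 by tert-butyl in place of trifluoromethyl on an aromatic carbon. With both measured compounds at the limit, nothing in the set shows that such an exchange moves potency, so the step from compound 2 to compound 3 is expected to be a number no higher from compound 2 to compound 3 (the limit leaves the size open), nothing beyond the scatter, most probably another limit. Compound 3 is therefore estimated at 40000 nM in this assay, within 10000 nM to 200000 nM.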

Compound 3, half-maximal inhibitory concentration: > 40000 nM
Compound 3 ended at the assay's limit; the forecaster's own chance of this, stated with the estimate: 80%; the middle value lies on the limit itself.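

No step can be read from compound 2 to compound 3, because neither gives a number and compound 1 stands alike: the limit of > 40000 nM in this assay, at which 3 of the 3 values shown sit. The compounds shown leave open whether any change to the shared core or its side groups gives a measurable value in this assay.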